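From Chloro to Bromo on an Aromatic Carbon

A few compounds are considered here, and "the series" means these few. Any claim that something is new, unique, unknown or untested is made for them only; others in the source may bear on it.

Compound 1, `CN(C)c1ccc(/C=C/C(=O)NS(=O)(=O)c2ccccc2)cc1`: 2.3 ug/mL
Compound 2, `CN(C)c1ccc(/C=C/C(=O)NS(=O)(=O)c2ccc(Cl)cc2)cc1`: 2.8 ug/mL

In a functional assay on B16-F10 cells (Mus musculus) for antiproliferative activity, read by ELISA and MTT assay, with a stated time of 48 h (a higher number here means a weaker inhibitor, a lower number a stronger inhibitor), compound 1 gives 2.3 ug/mL and compound 2 gives 2.8 ug/mL. Among the measured compounds shown here, compound 2 holds the highest of the two numbers, but its only neighbour, compound 1, lies within the scatter of it, so the two cannot be ranked. For the measured compounds named here, the single measured step, a 1.2-fold higher number from compound 1 to compound 2 (0.09 log units; within the scatter), put chloro in place of hydrogen on an aromatic carbon and barely moved the number.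

Compound 3, `CN(C)c1ccc(/C=C/C(=O)NS(=O)(=O)c2ccc(Br)cc2)cc1`, has not been measured. It differs from compound 2 by bromo in place of chloro on an aromatic carbon. Going by the values given here, the one step that bears on this change is a 1.2-fold higher number from compound 1 to compound 2 (0.09 log units; within the scatter): it also touched only this aromatic carbon and stayed within the scatter. The exchange of one halogen for another at that place is therefore expected to give no step beyond the scatter in this assay.

Compound 3 is expected to give about 2.9 ug/mL, with a range from 1.5 ug/mL to 5.5 ug/mL. This estimate means an expected step of a 1.0-fold higher number from compound 2 to compound 3 (0.02 log units; within the scatter).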

Compound 3, half-maximal inhibitory concentration: 4.2 ug/mL
Beside the measured number, compound 3's estimate is 1.4-fold (0.16 log units) below it, and the stated range covers the measured number.
By their numbers in this assay, from the lowest: compounds 1, 2 and 3 (each within the scatter of the next).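

The halogen exchange at this aromatic carbon, para to a large group, gives no separation in this assay (a 1.5-fold higher number from compound 2 to compound 3 (0.18 log units; within the scatter)), so chloro and bromo cannot be told apart here. The new comparison with hydrogen on that carbon (a 1.8-fold higher number from compound 1 to compound 3 (0.26 log units; within the scatter)) also stays within the scatter, so neither halogen can be distinguished from hydrogen at this place. Nothing further is at hand that could account for these numbers.

The compounds shown leave open whether a group of another kind on this carbon, such as an amine, a carboxylic acid or a longer chain, would give a step beyond the scatter. They also leave open whether chloro and bromo would stay this close elsewhere on the shared core.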